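Working notes: amino in place of hydroxy, compound 4

This account rests on a few compounds, and the source may have more. Where it says the series, first, only, none or still open, it means among the compounds named here.

In a functional assay on DU-145 cells (Homo sapiens) for cytotoxicity, read by trypan blue exclusion, with a stated time of 96 h (on this read-out higher numbers stand for weaker inhibition and lower numbers for stronger inhibition), so far:
compound 1 `COc1ccc(NS(=O)(=O)/C=C/c2c(OC)cc(OC)cc2OC)cc1` gives 200 nM
compound 2 `COc1cc(OC)c(/C=C/S(=O)(=O)Nc2ccc(OC)c(O)c2)c(OC)c1` gives 30 nM
compound 3 `COc1cc(OC)c(/C=C/S(=O)(=O)Nc2ccc(OC)c(OC(=O)C(C)(C)C3=C(C)C(=O)C=C(C)C3=O)c2)c(OC)c1` gives 9 nM

Compound 2 holds the middle of these three numbers, with compound 3 lower and compound 1 higher, and both gaps lie beyond the scatter. Compound 4 `COc1cc(OC)c(/C=C/S(=O)(=O)Nc2ccc(OC)c(N)c2)c(OC)c1` differs from compound 2 in one place (amino in place of hydroxy on an aromatic carbon), with amino in place of hydroxy on an aromatic carbon, ortho to a methoxy group and meta to a large group. In other words, 3-hydroxy-4-methoxyphenyl becomes 3-amino-4-methoxyphenyl.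

Among the measured compounds shown here, no measured step exchanges hydroxy for amino, so the size of this change is not known directly. The nearest evidence is a 6.7-fold lower number from compound 1 to compound 2 (0.82 log units; beyond the scatter) for hydroxy in place of hydrogen on an aromatic carbon, which is a modest step. That step adds a group, whereas compound 4 only exchanges one, so a smaller step is expected here, probably none beyond the scatter and, if anything, towards a lower number. In this assay the expected step is a 1.5-fold lower number from compound 2 to compound 4 (0.18 log units; within the scatter) as a working estimate. For compound 4 the estimated value is 20 nM with an expected range from 6 nM to 70 nM for now.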

Compound 4, half-maximal inhibitory concentration: 5 nM
Compound 4: middle estimate off by 4.0-fold (0.60 log units), on the high side, and the stated range ends above it.
By their numbers in this assay, from the lowest: compounds 4 and 3 (each within the scatter of the next); then compound 2; then compound 1.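

In this assay this place on the ring responds to which group sits there as well as to whether one is present: the exchange of hydroxy for amino, with heavy-atom, donor and acceptor counts unchanged, gives a 6.0-fold lower number from compound 2 to compound 4 (0.78 log units; beyond the scatter) and is printed as modest. Measured from the unsubstituted ring, amino gives a 40-fold lower number from compound 1 to compound 4 (1.60 log units; beyond the scatter) and is printed as large, whereas hydroxy gives a 6.7-fold lower number from compound 1 to compound 2 (0.82 log units; beyond the scatter) and is printed as modest, so among these three compounds the order at this place runs from hydrogen through hydroxy to amino. Nothing in hand bears on why amino and hydroxy part in this way.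

Open, from the compounds shown here alone, is how far the amino nitrogen itself can be altered, for instance as methylamino, dimethylamino or acetylamino, and whether an amide linking the large group of compound 3 through this nitrogen would read like that ester. Also open, going by these compounds, is whether the step from hydroxy to amino holds with ethoxy in place of the methoxy group on the same ring.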